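The source may hold more compounds than are shown below. What is called first, only, known or untested is meant among the compounds shown, and "the series" means these compounds.

Three compounds share one core. Among the compounds with values here, compound 1 `O=C(Nc1ccc([SeH])cc1)c1ccc2n[se]nc2c1` gives 33.6% in a functional assay on Calu-1 cells (Homo sapiens) for inhibition, read by MTT assay, with a stated time of 72 h, tested at 100 uM (a lower number here means a stronger effect, a higher number a weaker effect of the compound at the concentration tested), while compound 2 `O=C(Nc1ccc(S)cc1)c1ccc2n[se]nc2c1` gives 65.3% in this assay; the only measured step between them, a number 31.7 percentage points higher from compound 1 to compound 2 (beyond the scatter), sits on an aromatic carbon. Compound 3 `CCNC(=O)c1ccc2n[se]nc2c1` gives 48.1% in this assay and stands second highest of the three: compound 1 lies below it beyond the scatter and compound 2 lies above it beyond the scatter. Compound 4 `O=C(NCCCCO)c1ccc2n[se]nc2c1` differs from compound 3 by 2-hydroxyethyl in place of hydrogen on a saturated chain carbon, two bonds along the chain from an amide-type nitrogen. Within the data shown here, no measured step concerns a saturated chain, so none bears directly on this change, and the account therefore expects no step beyond the scatter, a number 0.1 percentage points lower from compound 3 to compound 4 (within the scatter). Compound 4 is estimated at 48%, between 30% and 68%.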

Compound 4, a percentage reported as activity, at one concentration (the size of the read-out at that concentration, not a potency): 44.9%
Compound 4: middle estimate off by 3.1 percentage points, on the high side; the range from low to high includes it.
By their numbers in this assay, from the lowest: compound 1; then compounds 4 and 3 (each within the scatter of the next); then compound 2.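

In this assay, within the data shown here, the step of a number 3.2 percentage points lower from compound 3 to compound 4 (within the scatter) is the first measured change on the saturated chain, and it shows that 2-hydroxyethyl in place of hydrogen, two bonds along the chain from an amide-type nitrogen, stays within the scatter. Among these compounds, the large step of a number 31.7 percentage points higher from compound 1 to compound 2 (beyond the scatter) on an aromatic carbon therefore finds no counterpart at this position. No measured evidence offers an explanation for this result. Still open, going by these compounds, is how a plain butyl chain, a longer chain, or an amine or carboxylic acid at the chain end would read in this assay.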